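The compounds below may be only part of what the source reports. "The series", "measured", "known", "first", "only" and "open" are said of these compounds alone.

Measured so far:
compound 1, `CCC1=C(O)c2c(oc(-c3ccccc3)cc2=O)C(CC)(CC)C1=O`: > 236 uM
compound 2, `CCC1=C(O)c2c(oc(-c3ccc(C)cc3)cc2=O)C(CC)(CC)C1=O`: 39.2 uM
compound 3, `CCC1=C(O)c2c(oc(-c3ccc(OC)c(C)c3)cc2=O)C(CC)(CC)C1=O`: 28.5 uM

In a functional assay on KB cells (Homo sapiens) for antiproliferative activity, read by sulforhodamine B assay, with a stated time of 3 days (a lower number here means that less compound is needed, a higher number that more compound is needed for the effect), compound 1 gives only a limit of the assay (the limit of > 236 uM in this assay, at which 1 of the 3 values shown sits). Compound 2 differs from compound 1 by methyl in place of hydrogen on an aromatic carbon, a step of an at least 6.0-fold lower number from compound 1 to compound 2 (0.77 log units; beyond the scatter). The core of compound 3 differs from that of compound 1 by 4-methoxy-3-methylphenyl in place of phenyl on an aromatic carbon; between compound 2 and compound 3 the step is a 1.4-fold lower number from compound 2 to compound 3 (0.14 log units; within the scatter), within the scatter.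

Compound 4, `CCC1=C(O)c2c(oc(-c3cc(C)c(OC)cc3C)cc2=O)C(CC)(CC)C1=O`, not yet measured, differs from compound 3 by methyl in place of hydrogen on an aromatic carbon. This is the same kind of change as from compound 1 to compound 2, but the place differs: ortho to a large group, meta to a methoxy group and para to a methyl group, rather than para to a large group. Going by these compounds, the step from compound 1 to compound 2 began at the limit of the assay for compound 1, so its true size is unknown. The ring of compound 3 already bears methyl and methoxy groups. A smaller step is expected, a 1.4-fold lower number from compound 3 to compound 4 (0.15 log units; within the scatter), resting on compound 3 at 28.5 uM and on an at least 6.0-fold lower number from compound 1 to compound 2 (0.77 log units; beyond the scatter). Compound 4 is expected at 20 uM, between 8 uM and 60 uM.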

Compound 4, concentration for half-maximal effect: 36.6 uM
Estimate against measurement, compound 4: 1.8-fold (0.26 log units) below, and the stated range covers the measured number.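

Methyl in place of hydrogen on an aromatic carbon does not carry over as a single step in this assay; on a ring already bearing methyl and methoxy groups it gives a 1.3-fold higher number from compound 3 to compound 4 (0.11 log units; within the scatter), and the two cases differ: the same change on two cores in this assay, an at least 6.0-fold lower number (0.77 log units; beyond the scatter) from compound 1 to compound 2 and a 1.3-fold higher number (0.11 log units; within the scatter) from compound 3 to compound 4, at least 7.7-fold (0.88 log units) apart, beyond the scatter of two such steps

The earlier step starts from a limit, so it has no exact size: the limit of > 236 uM in this assay, at which 1 of the 4 values shown sits.

The new methyl also sits ortho to a large group, so this pair of steps does not separate the effect of the core from that of the place on the ring.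

Open, going by these compounds, is whether an amine or a longer chain on that same carbon would give a step beyond the scatter in this assay. Also open, on these data alone, is how methyl ortho to a large group would behave on the core of compound 1.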